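Changing the Pyrazole Link on a Long Chain

The source may hold more compounds than are shown below. What is called first, only, known or untested is meant among the compounds shown, and "the series" means these compounds.

- compound 1 `CCCCCCCCCCCC[C@@H](O)[C@H]1CC[C@H]([C@H](O)CCCCCCCCCCNC(=O)c2ccnn2C)O1`: 12900 nM
- compound 2 `CCCCCCCCCCCC[C@@H](O)[C@H]1CC[C@H]([C@H](O)CCCCCCCCCCN(C)C(=O)c2ccnn2C)O1`: 8510 nM
- compound 3 `CCCCCCCCCCCC[C@@H](O)[C@H]1CC[C@H]([C@H](O)CCCCCCCCCCNCc2ccnn2C)O1`: 8710 nM

In a functional assay on A549 cells (Homo sapiens) for inhibition, read by sulforhodamine B assay, with a stated time of 48 h (on this read-out lower numbers stand for stronger inhibition of growth and higher numbers for weaker inhibition of growth), compound 3 gives 8710 nM, a value within the scatter of those of both other measured compounds. The next compound is compound 4 `CCCCCCCCCCCC[C@@H](O)[C@H]1CC[C@H]([C@H](O)CCCCCCCCCCC(=O)Nc2ccnn2C)O1`, and the change is (1-methyl-1H-pyrazol-5-yl)carbamoyl in place of ((1-methyl-1H-pyrazol-5-yl)methyl)amino on a saturated chain carbon, ten or more bonds along the chain from an oxygen on a saturated carbon and a saturated ring carbon. Put simply, (1-methyl-1H-pyrazol-5-yl)carbamoyl stands in place of ((1-methyl-1H-pyrazol-5-yl)methyl)amino on a saturated chain carbon.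

Going by the values given here, none of the measured steps is this exact swap, but all three alter how the 1-methyl-1H-pyrazol-5-yl group is linked to the chain. They are a 1.5-fold lower number from compound 1 to compound 2 (0.18 log units; within the scatter), a 1.5-fold lower number from compound 1 to compound 3 (0.17 log units; within the scatter) and a 1.0-fold higher number from compound 2 to compound 3 (0.01 log units; within the scatter). All three stay within the scatter, so no shift beyond the scatter is expected here, although this small set cannot rule one out. In this assay the expected step is a 1.1-fold higher number from compound 3 to compound 4 (0.06 log units; within the scatter). For compound 4 the estimated value is 10000 nM, with an expected range from 5000 nM to 20000 nM.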

Compound 4, concentration for 50% growth inhibition: 100000 nM
For compound 4 the middle estimate is 10-fold (1.00 log units) below the measured one; the whole stated range lies below it.
By their numbers in this assay, from the lowest: compounds 2, 3 and 1 (each within the scatter of the next); then compound 4.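

In this assay, the way the 1-methyl-1H-pyrazol-5-yl group is linked to the chain turns out to matter after all, with weaker growth inhibition in an 11-fold higher number from compound 3 to compound 4 (1.06 log units; beyond the scatter) and in a 12-fold higher number from compound 2 to compound 4 (1.07 log units; beyond the scatter). Compound 1 and compound 4 carry the same carbonyl and nitrogen in opposite order, and that reversal alone gives a 7.8-fold higher number from compound 1 to compound 4 (0.89 log units; beyond the scatter), so the direction of the amide counts here and not merely its presence. Nothing available explains this loss of activity.

From the compounds shown here alone, it remains open whether the loss belongs to the reversed amide itself or could be recovered by a small change around it. A methyl on the carbamoyl nitrogen of compound 4, or a longer chain leading to the carbamoyl, would test this.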